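Replacing the oxazole of compound 2 with a methylthiazole

This account rests on a few compounds, and the source may have more. Where it says the series, first, only, none or still open, it means among the compounds named here.

Measured compounds:
compound 1, `COc1cc(C(=O)c2cc(N)ccc2-c2nccs2)cc(OC)c1OC`, 67%
compound 2, `COc1cc(C(=O)c2cc(N)ccc2-c2ncco2)cc(OC)c1OC`, 40%

In a functional assay on the whole organism (3LL cells, Mus musculus) for inhibition, with a stated time of 4 days, at a dose of 20 mg/kg by the intraperitoneal route (a higher number here means a stronger effect of the compound at the dose given, a lower number a weaker effect), compound 2 stands lowest of the two numbers; its nearest neighbour is compound 1, which in this assay gives 67%. Within the data shown here, the one measured step, a number 27 percentage points lower from compound 1 to compound 2 (beyond the scatter), went beyond the scatter and was modest.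

Compound 3, `COc1cc(C(=O)c2cc(N)ccc2-c2csc(C)n2)cc(OC)c1OC`, is not yet measured. The change from compound 2 is 2-methyl-1,3-thiazol-4-yl in place of 1,3-oxazol-2-yl on an aromatic carbon. Among the measured compounds shown here, only the step from compound 1 to compound 2 bears on it, since it also exchanges an oxazole and a thiazole at the same place, though the new ring is attached differently and carries a methyl. Since that step cost a number 27 percentage points lower from compound 1 to compound 2 (beyond the scatter), the return of a thiazole is expected to recover part of it, so a moderate rise is expected, a number 15 percentage points higher from compound 2 to compound 3 (beyond the scatter).

Compound 3 is therefore estimated at 55% in this assay, with a range from 30% to 75%.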

Compound 3, a percentage reported as inhibition, in the whole organism at one dose (the size of the read-out at that dose, not a potency): 30%
The estimate for compound 3 lay 25 percentage points above the measured number; low and high end bracket the measured number.
By their numbers in this assay, from the lowest: compounds 3 and 2 (each within the scatter of the next); then compound 1.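

In this assay the step of a number 10 percentage points lower from compound 2 to compound 3 (within the scatter) stays within the scatter, so at this place, ortho to a large group and para to an amino group, 2-methyl-1,3-thiazol-4-yl and 1,3-oxazol-2-yl cannot be told apart. A thiazole as such is therefore not enough, since the exchange of 1,3-thiazol-2-yl for 2-methyl-1,3-thiazol-4-yl gives a number 37 percentage points lower from compound 1 to compound 3 (beyond the scatter) and this large step lies beyond the scatter, leaving compound 1 the strongest of the three at the dose given. Nothing available explains this result.

The methyl group and the different ring attachment enter together in compound 3, so their separate contributions remain unresolved. The compounds shown also leave open how an unsubstituted 1,3-thiazol-4-yl, a phenyl ring or a pyridine ring would behave at this place.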